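One aryl swap in a cell-growth assay

This account rests on a few compounds, and the source may have more. Where it says the series, first, only, none or still open, it means among the compounds named here.

Compound 1 `O=C(Nc1ccc(Oc2ccnc3[nH]ccc23)cc1)c1cn(-c2ccc(C(F)(F)F)cc2Cl)c2ccccc2c1=O` is recorded in a functional assay on HepG2 cells (Homo sapiens) for inhibition, read by MTT assay, with a stated time of 72 h (a higher number here means a weaker inhibitor, a lower number a stronger inhibitor), as "not determined" (no result reported), so it carries no number. For the measured compounds named here, compound 2 `O=C(Nc1ccc(Oc2ccnc3[nH]ccc23)cc1)c1cn(-c2ccc(F)c(Cl)c2)c2ccccc2c1=O` gives 1120 nM in this assay; as the only number on show, it is the sole reference point, and no step between measured compounds exists to calibrate against. Compound 3 `COc1ccc(-n2cc(C(=O)Nc3ccc(Oc4ccnc5[nH]ccc45)cc3)c(=O)c3ccccc32)cc1` differs from compound 2 in one place: 4-methoxyphenyl in place of 3-chloro-4-fluorophenyl on an aromatic nitrogen. Going by the values given here, with no measured step to lean on, the expected shift is small, within or just beyond the scatter toward weaker inhibition: a 1.3-fold higher number from compound 2 to compound 3 (0.13 log units; within the scatter). Compound 3 is therefore estimated at 1500 nM, within a range from 500 nM to 4500 nM.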

Compound 3, half-maximal inhibitory concentration: 5950 nM
Beside the measured number, compound 3's estimate is 4.0-fold (0.60 log units) below it; the whole stated range lies below it.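

The aryl group on this aromatic nitrogen matters in this assay: 4-methoxyphenyl in place of 3-chloro-4-fluorophenyl gives a 5.3-fold higher number from compound 2 to compound 3 (0.73 log units; beyond the scatter), a clear loss of inhibition even though both groups have the same heavy-atom count. For the compounds shown here, this is the first measured step at this position, and it rests on a single pair. Nothing in the data given explains the change. Still open, from the compounds shown here alone, is whether the chlorine, the fluorine or the methoxy accounts for the shift, and how a phenyl ring carrying an amine or a carboxylic acid would behave here.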